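Replacing an Aminoethoxy Tail with a Pyrrolidinylethylamino Tail

The source may hold more compounds than are shown below. What is called first, only, known or untested is meant among the compounds shown, and "the series" means these compounds.

Measured compounds:
compound 1, `COc1cc(OC)c2c(=O)cc(-c3ccc(OCCCN(C)C)cc3)oc2c1`, 36%
compound 2, `COc1cc(OC)c2c(=O)cc(-c3ccc(OCCN)cc3)oc2c1`, 6%

In a functional assay (Homo sapiens) for antiproliferative activity, read by resazurin assay, with a stated time of 48 h, tested at 5 uM (a higher number here means a stronger effect of the compound at the concentration tested, a lower number a weaker effect), compound 2 stands lowest of the two numbers shown; its nearest neighbour is compound 1, and the step of a number 30 percentage points lower from compound 1 to compound 2 (beyond the scatter) lies beyond the scatter. Compound 3, `COc1cc(OC)c2c(=O)cc(-c3ccc(NCCN4CCCC4)cc3)oc2c1`, is not yet measured. It differs from compound 2 by (2-(pyrrolidin-1-yl)ethyl)amino in place of 2-aminoethoxy on an aromatic carbon, placed on an aromatic carbon of a six-membered aromatic ring of carbon only, para to a large group. Among the compounds with values here, only one measured step bears on this change: the loss in going from compound 1 to compound 2, where amino replaced (dimethylamino)methyl on a saturated chain carbon. Compound 3 brings back a tertiary amine on a two-carbon chain, so the account expects a gain that partly reverses that loss, estimated as a number 24 percentage points higher from compound 2 to compound 3 (beyond the scatter). Compound 3 is therefore estimated at 30%, with a range from 10% to 50%.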

Compound 3, a percentage reported as inhibition, at one concentration (the size of the read-out at that concentration, not a potency): 21%
Compound 3: middle estimate off by 9 percentage points, on the high side, within the range that was stated.
By their numbers in this assay, from the lowest: compound 2; then compound 3; then compound 1.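

In this assay, putting (2-(pyrrolidin-1-yl)ethyl)amino in place of 2-aminoethoxy on this aromatic carbon gives a number 15 percentage points higher from compound 2 to compound 3 (beyond the scatter) and shows that the read-out at this position can rise with a tail that ends in a five-membered non-aromatic ring and has no oxygen on the aromatic ring. Measured against the 3-(dimethylamino)propoxy tail, the same new tail gives a number 15 percentage points lower from compound 1 to compound 3 (beyond the scatter) and so does not reach the level of that tail. Nothing at hand gives a reason for either step.

Compound 3 changes the link to the aromatic ring and the end of the tail in a single step, so the compounds shown leave open which of the two accounts for the gain. Going by these compounds, a 2-(pyrrolidin-1-yl)ethoxy tail would separate them, and how a piperidine ring or a longer chain would read in this assay also remains open.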